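The source may hold more compounds than are shown below. What is called first, only, known or untested is meant among the compounds shown, and "the series" means these compounds.

Compound 1 `CCc1nc(-c2ccc(Cl)cc2Cl)c(CC)nc1NC(CC)CC` gives 4.1 nM in an assay on IMR-32 cells for displacement of a labelled ligand from corticotropin-releasing factor receptor 1 (Homo sapiens), read by scintillation counting, with a stated time of 2 h (a higher number here means a weaker inhibitor, a lower number a stronger inhibitor), the lowest of the three numbers measured. Compound 3 `CCc1nc(-c2ccc(Cl)cc2Cl)c(OC)nc1NC(CC)CC` gives 8 nM after a 2.0-fold higher number from compound 1 to compound 3 (0.29 log units; within the scatter), while compound 2 `CCc1nc(NC(CC)CC)c(F)nc1-c1ccc(Cl)cc1Cl` gives 167 nM after a 41-fold higher number from compound 1 to compound 2 (1.61 log units; beyond the scatter). Compound 4 `CCc1nc(-c2ccc(Cl)cc2Cl)c(CC)nc1CC(CC)CC` differs from compound 1 in another way: 2-ethylbutyl in place of (pentan-3-yl)amino on an aromatic carbon. Neither measured step touches this position, so both bear on it only indirectly; they show that a small change on the shared core can be nearly neutral or very costly. With the hydrogen-bond donor and acceptor gone, a moderate step toward a higher number is expected, a 6.1-fold higher number from compound 1 to compound 4 (0.79 log units; beyond the scatter). Compound 4 is therefore estimated at 25 nM, with a range from 6 nM to 120 nM.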

Compound 4, inhibition constant: 68 nM
Compound 4: the middle estimate sits 2.7-fold (0.43 log units) below what was measured, and the stated range covers the measured number.
By their numbers in this assay, from the lowest: compounds 1 and 3 (each within the scatter of the next); then compound 4; then compound 2.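

Replacing (pentan-3-yl)amino with 2-ethylbutyl gives a 17-fold higher number from compound 1 to compound 4 (1.22 log units; beyond the scatter), so at this position a chain with the same number of heavy atoms does not keep the low number of compound 1. Within the data shown here, the change swaps the nitrogen attached to the shared core for carbon and removes the hydrogen-bond donor and acceptor, showing that this position, untouched by the earlier steps, is also sensitive to change. No measurement here explains the loss.

As far as these compounds go, it remains open whether an ether oxygen in that linking place would restore the number. A methylated amine would test whether the amine hydrogen matters.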